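Trifluoroacetyl for Phenyl on a Pyrrole Reductase Inhibitor

The source may hold more compounds than are shown below. What is called first, only, known or untested is meant among the compounds shown, and "the series" means these compounds.

Compound 1: `CCOC(=O)c1c(-c2ccccc2)c(-c2ccccc2)n(CC[C@@H]2C[C@@H](O)CC(=O)O2)c1C`, 4000 nM
Compound 2: `CC(C)c1cc(-c2ccccc2)c(-c2ccc(F)cc2)n1CC[C@@H]1C[C@@H](O)CC(=O)O1`, 347 nM

In an assay for inhibition of 3-hydroxy-3-methylglutaryl-coenzyme A reductase (Rattus norvegicus) (a lower number here means a stronger inhibitor, a higher number a weaker inhibitor), compound 1 gives 4000 nM, while compound 2 gives 347 nM, the lower of the two numbers shown. Compound 3, `CC(C)c1cc(C(=O)C(F)(F)F)c(-c2ccc(F)cc2)n1CC[C@@H]1C[C@@H](O)CC(=O)O1`, differs from compound 2 by (trifluoromethyl)carbonyl in place of phenyl on an aromatic carbon. Within the data shown here, no measured pair shows such a change, so nothing here fixes its size. A step from compound 2 to compound 3 of about a 4.3-fold higher number from compound 2 to compound 3 (0.64 log units; beyond the scatter) toward a higher number is expected. For compound 3 the estimate in this assay is 1500 nM, with a range of 400 nM to 6000 nM.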

Compound 3, half-maximal inhibitory concentration: 800 nM
Beside the measured number, compound 3's estimate is 1.9-fold (0.27 log units) above it; measured number inside the range.
By their numbers in this assay, from the lowest: compound 2; then compound 3; then compound 1.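

In this assay, replacing the phenyl with (trifluoromethyl)carbonyl, on the aromatic carbon next to the ring atom that bears the 4-fluorophenyl group, gives a 2.3-fold higher number from compound 2 to compound 3 (0.36 log units; beyond the scatter) as a modest step. At this position, then, an aromatic ring is not needed for inhibition, although the phenyl compound keeps the lower number. No measured evidence explains the size of this step.

As far as these compounds go, it remains open whether the carbonyl or the trifluoromethyl matters more here. A plain acetyl, a benzoyl or a primary amide at this position would help separate them.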